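The compounds below may be only part of what the source reports. "The series", "measured", "known", "first", "only" and "open" are said of these compounds alone.

Measured compounds in a functional assay on MGC-803 cells (Homo sapiens) for antiproliferative activity, read by MTT assay, with a stated time of 48 h; a lower number here means a stronger inhibitor, a higher number a weaker inhibitor:
- compound 1, `CCOc1ccc(NC(=O)Nc2cccc(CNc3nccnc3Cl)c2)cc1`, 7240 nM
- compound 2, `O=C(Nc1cccc(Cl)c1)Nc1cccc(CNc2nccnc2Cl)c1`, 5330 nM
- compound 3, `O=C(Nc1cccc(CNc2nccnc2Cl)c1)Nc1ccccc1F`, 6440 nM

Compound 1 gives the highest of the three numbers, but its nearest neighbour compound 3 and its furthest neighbour compound 2 both lie within the scatter of it, so the three compounds cannot be put in any order of strength on these data alone.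

Compound 4, `Cc1ccc(NC(=O)Nc2cccc(CNc3nccnc3Cl)c2)cc1C`, has not yet been measured. It differs from compound 1 only in the group on the urea nitrogen: 3,4-dimethylphenyl in place of 4-ethoxyphenyl on an amide-type nitrogen.

The measured steps that bear on this are the two other swaps of the aryl group on the same amide-type nitrogen, starting from compound 1. a 1.4-fold lower number from compound 1 to compound 2 (0.13 log units; within the scatter). a 1.1-fold lower number from compound 1 to compound 3 (0.05 log units; within the scatter). The step between those two variants, a 1.2-fold higher number from compound 2 to compound 3 (0.08 log units; within the scatter), is likewise within the scatter. Every change of the aryl group seen so far in this assay has therefore left the number where it was, and the move to 3,4-dimethylphenyl is expected to do the same: a step of a 1.1-fold lower number from compound 1 to compound 4 (0.05 log units; within the scatter) that does not rise above the scatter, with no direction called.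

Compound 4 is accordingly estimated at 6500 nM in this assay, with a range of 3200 nM to 13000 nM.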

Compound 4, half-maximal inhibitory concentration: 9870 nM
For compound 4 the middle estimate is 1.5-fold (0.18 log units) below the measured one, within the range that was stated.
By their numbers in this assay, from the lowest: compounds 2, 3, 1 and 4 (each within the scatter of the next).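

In this assay, replacing 4-ethoxyphenyl with 3,4-dimethylphenyl on the amide-type nitrogen gives a 1.4-fold higher number from compound 1 to compound 4 (0.13 log units; within the scatter) and removes the oxygen from this group, yet the step stays within the scatter. Against the two halogen-bearing aryl groups the new group gives a 1.5-fold higher number from compound 3 to compound 4 (0.19 log units; within the scatter) and a 1.9-fold higher number from compound 2 to compound 4 (0.27 log units; within the scatter) and, although the last is the largest step yet seen at this position, it too stays within the scatter, so a fourth substituted phenyl group still yields no order among the compounds and no effect of this position can be claimed. No supporting measurement is available to explain any of these steps.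

The compounds shown leave open whether any group at this position can move the number beyond the scatter, for instance a cyclohexyl group, a phenyl carrying a carboxylic acid or an amine, or a longer alkoxy chain. They also leave open how much the chlorine and the rest of the shared core contribute, as all four compounds carry them unchanged.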